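The source may hold more compounds than are shown below. What is called first, only, known or untested is meant among the compounds shown, and "the series" means these compounds.

In an assay on cells for inhibition of histone deacetylase 8 (Homo sapiens), read by fluorescence, with a stated time of 30 min (a higher number here means a weaker inhibitor, a lower number a stronger inhibitor), compound 1 `O=C1NC(=O)/C(=C\c2ccc(OCC(=O)N3N=C(c4ccccc4)CC3c3ccccc3)cc2)S1` gives 20000 nM. Two close relatives have been measured alongside it: compound 2 `O=C1NC(=O)/C(=C\c2ccc(OCC(=O)N3N=C(c4ccccc4)CC3c3ccc(F)cc3)cc2)S1` gives 26000 nM, and compound 3 `Cc1ccc(C2CC(c3ccccc3)=NN2C(=O)COc2ccc(/C=C3/SC(=O)NC3=O)cc2)cc1` gives 31000 nM. The step of a 1.3-fold higher number from compound 1 to compound 2 (0.11 log units; within the scatter) and the step of a 1.6-fold higher number from compound 1 to compound 3 (0.19 log units; within the scatter) both stay within the scatter, as does a 1.2-fold higher number from compound 2 to compound 3 (0.08 log units; within the scatter), so the three compounds stand level in this assay, with compound 1 showing a number that none of the others separates from.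

Compound 4 `O=C1NC(=O)/C(=C\c2ccc(OCC(=O)N3N=C(c4ccc(F)cc4)CC3c3ccccc3)cc2)S1` differs from compound 1 by fluoro in place of hydrogen on an aromatic carbon. Among the measured compounds shown here, the only measured step that bears on this change is the one from compound 1 to compound 2, where a fluoro in place of hydrogen elsewhere in the molecule left the number within the scatter. A similar outcome is therefore expected here: the estimated step of a 1.2-fold higher number from compound 1 to compound 4 (0.08 log units; within the scatter) lies within the scatter, with at most a slight drift toward a higher number. Compound 4 is thus expected to give about 24000 nM, within a range from 12000 nM to 48000 nM.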

Compound 4, half-maximal inhibitory concentration: > 50000 nM
Compound 4: a limit, no number; the forecaster's own chance of this, stated with the estimate: 10%; at least 2.0-fold (0.31 log units) between middle value and limit.
By their numbers in this assay, from the lowest: compounds 1, 2 and 3 (each within the scatter of the next). At a limit, above all of these: compound 4.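

At this position, para to a large group, fluoro in place of hydrogen gives an at least 2.5-fold higher number from compound 1 to compound 4 (0.39 log units; beyond the scatter), the only step shown that goes beyond the scatter. The same exchange elsewhere in the molecule gives a 1.3-fold higher number from compound 1 to compound 2 (0.11 log units; within the scatter), so among these compounds the outcome of adding fluoro depends on where it sits and not on the exchange alone. The value of compound 4 in this assay is a limit and not a number, so the true size of this step stays unknown: the limit of > 50000 nM in this assay, at which 1 of the 4 values shown sits.

The compounds shown leave open whether a methyl, a methoxy group or an amine in this same place would also carry the number beyond the scatter. They also leave open whether chloro, in place of fluoro, would do the same.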